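Phenyl in Place of Butyl: Expected Antiproliferative Value

The compounds below may be only part of what the source reports. "The series", "measured", "known", "first", "only" and "open" are said of these compounds alone.

Measured compounds:
compound 1 `O[C@@H]1[C@@H](OCc2ccccc2)[C@H](OCc2ccccc2)[C@@H](COCc2ccccc2)O[C@@H]1CC1CCCCC1` — 17200 nM
compound 2 `CCCC[C@H]1O[C@H](COCc2ccccc2)[C@@H](OCc2ccccc2)[C@H](OCc2ccccc2)[C@H]1O` — "not active" (no number reported)

In a functional assay on HL-60 cells (Homo sapiens) for antiproliferative activity, read by MTT assay (on this read-out lower numbers stand for stronger inhibition and higher numbers for weaker inhibition), compound 1 gives 17200 nM, a weak result. Compound 2 is recorded in this assay only as "not active" (no number reported), so no single number fixes where compound 2 stands; it can be said only that it did not show measurable inhibition where compound 1 did. Compound 3 `O[C@@H]1[C@@H](OCc2ccccc2)[C@H](OCc2ccccc2)[C@@H](COCc2ccccc2)O[C@@H]1c1ccccc1` is the next member and differs from compound 2 in one place: phenyl in place of butyl on a saturated ring carbon. Within the data shown here, no measured pair shows this same change, so the size of the step from compound 2 to compound 3 in this assay cannot be read from a companion pair. Both measured compounds are weak or inactive, and the change does not introduce any hydrogen-bond donor or acceptor, so a large move toward strong inhibition is not anticipated; a value near that of compound 1, or no measurable value at all, is the more likely outcome. Compound 3 is therefore expected to give about 20000 nM in this assay, with a plausible range from 5000 nM to 80000 nM.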

Compound 3, half-maximal inhibitory concentration: "not active" (no number reported)
No number was reported for compound 3; no gap can be computed for the estimate.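

In this assay, among these compounds, compound 2 and compound 3 are both recorded only as "not active", without a number, and no step from butyl to phenyl can be read between them. Nothing shown bears on this result. The compounds shown leave open how large the effect of that change is on this read-out.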